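Methoxy in Place of Methyl: A Small Expected Step

The compounds below may be only part of what the source reports. "The series", "measured", "known", "first", "only" and "open" are said of these compounds alone.

Compound 1 `C#CCOc1ccc(/C=C/C(=O)c2cccc(C)c2)cc1OC` has the lower of the two numbers in a functional assay on CCRF-CEM cells (Homo sapiens) for cytotoxicity, with a stated time of 72 h (a higher number here means a weaker inhibitor, a lower number a stronger inhibitor), giving 8820 nM. Compound 2 `C=CCOc1ccc(C=O)cc1OC` gives 14000 nM, which sits within the scatter of compound 1, so the two cannot be ranked against each other. Compound 3 `C#CCOc1ccc(C(CC(=O)c2cccc(Br)c2)CC(=O)c2cccc(Br)c2)cc1OC` gives > 50000 nM, which is a limit of the assay rather than a number (the limit of > 50000 nM in this assay, at which 1 of the 3 values shown sits). Compound 4 `C#CCOc1ccc(/C=C/C(=O)c2cccc(OC)c2)cc1OC` differs from compound 1 in one place: methoxy in place of methyl on an aromatic carbon. For the measured compounds named here, no measured pair shows this change, so there is no step to draw on. The estimated step of a 1.1-fold lower number from compound 1 to compound 4 (0.04 log units; within the scatter) is expected to be none beyond the scatter. Compound 4 is therefore estimated at 8000 nM, with a likely range from 3000 nM to 25000 nM.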

Compound 4, half-maximal inhibitory concentration: 5590 nM
Beside the measured number, compound 4's estimate is 1.4-fold (0.16 log units) above it; the measured number falls inside the stated range.
By their numbers in this assay, from the lowest: compounds 4, 1 and 2 (each within the scatter of the next, the first and the last beyond it). At a limit, above all of these: compound 3.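

In this assay, replacing the 3-methylphenyl with the 3-methoxyphenyl gives a 1.6-fold lower number from compound 1 to compound 4 (0.20 log units; within the scatter), so the two compounds cannot be ranked and this position tolerates the methoxy group. For the compounds shown here, this is the first direct reading of the change, as no earlier pair of compounds showed it. Nothing measured in the data shown bears on this step.

On these data alone, whether an amine or a carboxylic acid at this place would move the number beyond the scatter remains open. So does whether the same replacement would behave alike on a different core.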